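This account rests on a few compounds, and the source may have more. Where it says the series, first, only, none or still open, it means among the compounds named here.

Measured compounds and their values:
Compound 1 `COc1ccccc1-n1cc(COc2c(/C=C\C(=O)O)ccc(OC)c2CC=C(C)C)nn1` gives 41500 nM in a functional assay on NCI-H322 cells (Homo sapiens) for cytotoxicity, read by MTT assay, with a stated time of 24 h; on this read-out higher numbers stand for weaker inhibition and lower numbers for stronger inhibition.
Compound 2 `COc1ccc(/C=C\C(=O)O)c(OCc2cn(-c3ccccc3F)nn2)c1CC=C(C)C` gives 45600 nM in this assay.
Compound 3 `COc1cccc(-n2cc(COc3c(/C=C\C(=O)O)ccc(OC)c3CC=C(C)C)nn2)c1` gives 25200 nM in this assay.

Compound 3 has the lowest of the three numbers, but its separation from compound 1 (a 1.6-fold lower number from compound 1 to compound 3 (0.22 log units; within the scatter)) and from compound 2 (a 1.8-fold lower number from compound 2 to compound 3 (0.26 log units; within the scatter)) stays within the scatter, so no order among the three can be claimed. Compound 4 `COc1ccc(/C=C\C(=O)O)c(OCc2cn(-c3cccc(C#N)c3)nn2)c1CC=C(C)C` is not yet measured. It differs from compound 3 in one place: cyano in place of methoxy on an aromatic carbon. The step that bears most directly on this change is the swap of one small substituent for another on the phenyl carried by the aromatic nitrogen, a 1.1-fold higher number from compound 1 to compound 2 (0.04 log units; within the scatter), which did not move the number beyond the scatter. The shifts of the phenyl substituent pattern in a 1.6-fold lower number from compound 1 to compound 3 (0.22 log units; within the scatter) and a 1.8-fold lower number from compound 2 to compound 3 (0.26 log units; within the scatter) were likewise within the scatter. On this basis the change from methoxy to cyano is expected to leave the number essentially where it is, with a 1.1-fold higher number from compound 3 to compound 4 (0.03 log units; within the scatter) expected to fall inside the scatter. Compound 4 is therefore estimated at 27000 nM in this assay, within a range of 11000 nM to 65000 nM.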

Compound 4, half-maximal inhibitory concentration: 26500 nM
Compound 4: middle estimate off by 1.0-fold (0.01 log units), on the high side, within the range that was stated.
By their numbers in this assay, from the lowest: compounds 3, 4, 1 and 2 (each within the scatter of the next).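

In this assay, among the compounds shown here, the change from 3-methoxyphenyl to 3-cyanophenyl, on an aromatic carbon meta to a large group, gives a 1.1-fold higher number from compound 3 to compound 4 (0.02 log units; within the scatter) and thus adds what the earlier compounds could not show: at this place, cyano and methoxy cannot be told apart in this read-out. The comparisons with the other two phenyl groups, a 1.7-fold lower number from compound 2 to compound 4 (0.24 log units; within the scatter) and a 1.6-fold lower number from compound 1 to compound 4 (0.19 log units; within the scatter), also stay within the scatter, so none of the four phenyl groups shown is separated from the others. No evidence is available that would explain this lack of separation.

From the compounds shown here alone, whether an amine, a carboxylic acid or a longer chain at this place would move the number beyond the scatter remains open. So does whether a change elsewhere on the shared core would do so.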